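Shifting the triazole aryl group from compound 3 to compound 4

The source may report more compounds than this note shows. Statements on the series, on what has been measured and on what is new or still open speak of the compounds shown alone.

Of the compounds shown here, three sharing one core have been measured in a functional assay on OVCAR-3 cells (Homo sapiens) for antiproliferative activity, read by MTT assay, with a stated time of 24 h; on this read-out lower numbers stand for stronger inhibition and higher numbers for weaker inhibition. Compound 1 `Cc1ccccc1-n1cc(-c2ccccc2NS(=O)(=O)c2c[nH]c(=O)[nH]c2=O)nn1` gives 6550 nM in this assay, compound 2 `Cc1ccc(-n2cc(-c3ccccc3NS(=O)(=O)c3c[nH]c(=O)[nH]c3=O)nn2)cc1` gives 2190 nM, and compound 3 `Cc1ccccc1-n1cc(-c2cccc(NS(=O)(=O)c3c[nH]c(=O)[nH]c3=O)c2)nn1` gives 6230 nM. Among these three numbers compound 3 stands second highest; its nearest neighbour is compound 1, a difference within the scatter, while compound 2 lies a little further off with a lower number beyond the scatter.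

Compound 4 `O=c1[nH]cc(S(=O)(=O)Nc2cccc(-c3cn(-c4ccc(F)cc4)nn3)c2)c(=O)[nH]1` is not yet measured. It differs from compound 3 in one place: 4-fluorophenyl in place of 2-methylphenyl on an aromatic nitrogen.

Among the compounds with values here, one measured step bears on this change. Going from compound 1 to compound 2, where 4-methylphenyl replaces 2-methylphenyl on the aromatic nitrogen, the number fell: a 3.0-fold lower number from compound 1 to compound 2 (0.48 log units; beyond the scatter). The change from compound 3 to compound 4 likewise exchanges 2-methylphenyl for a phenyl bearing its single substituent in the 4-position, though the group entering is fluorine rather than methyl. A modest downward step is therefore expected, though smaller than the measured one is allowed for, since the substituent is not the same.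

For compound 4 in this assay the expected value is 3000 nM, with a range from 1200 nM to 8000 nM, corresponding to an expected step of a 2.1-fold lower number from compound 3 to compound 4 (0.32 log units; beyond the scatter).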

Compound 4, half-maximal inhibitory concentration: > 20000 nM
Compound 4: a limit, no number; the forecaster's own chance of this, stated with the estimate: 5%; middle value at least 6.6-fold (0.82 log units) from the limit.
By their numbers in this assay, from the lowest: compound 2; then compounds 3 and 1 (each within the scatter of the next). At a limit, above all of these: compound 4.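

In this assay compound 4 gives > 20000 nM, which is a limit of the assay and not a number. On the aromatic nitrogen, replacing 2-methylphenyl therefore does not move the number in a single direction: 4-fluorophenyl gives an at least 3.2-fold higher number from compound 3 to compound 4 (0.50 log units; beyond the scatter), whereas 4-methylphenyl gave a 3.0-fold lower number from compound 1 to compound 2 (0.48 log units; beyond the scatter). These two steps start from different compounds and bring in different groups, and the new one can be read only as a lower bound on its size: the limit of > 20000 nM in this assay, at which 1 of the 4 values shown sits.

The compounds shown leave open whether the opposite direction goes with the entering group or with the core, a question that 4-fluorophenyl on the core of compound 1 and 4-methylphenyl on the core of compound 3 would each address. They also leave open how the number would respond to a phenyl group carrying an amine or a carboxylic acid on the same nitrogen, and whether any such group would bring the value back within a measurable range in this assay.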